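A few compounds are considered here, and "the series" means these few. Any claim that something is new, unique, unknown or untested is made for them only; others in the source may bear on it.

Measured so far:
Compound 1, `CNc1nc(NCc2ccc(C(=O)NC3CCN(Cc4ccc(F)cc4)CC3)cc2)c2cc(C)ccc2n1`: 1200 nM
Compound 2, `CCNc1nc(NCc2ccc(NC(=O)c3ccc(F)cc3)cc2)c2ccccc2n1`: 1400 nM
Compound 3, `CCNc1nc(NCc2ccc(NC(=O)c3ccc(F)cc3)cc2Cl)c2ccccc2n1`: 1500 nM

All three compounds were tested in a functional assay on HCT-116 cells (Homo sapiens) for inhibition, read by luminescence and resazurin assay, with a stated time of 3 days; a lower number here means a stronger inhibitor, a higher number a weaker inhibitor. Compound 2 sits among values that cannot be told apart: its number is within the scatter of compound 3 and also within the scatter of compound 1, so none of the three stands out as stronger or weaker.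

Compound 4, `CN(C)CCCNc1nc(NCc2ccc(NC(=O)c3ccc(F)cc3)cc2)c2ccccc2n1`, has not yet been measured. It differs from compound 2 in one place: (dimethylamino)methyl in place of hydrogen on a saturated chain carbon, two bonds along the chain from a nitrogen on an aromatic ring. For the measured compounds named here, the only single-point step among the measured compounds is a 1.1-fold higher number from compound 2 to compound 3 (0.03 log units; within the scatter), and that change sits on an aromatic ring, not on the chain attached to the ring nitrogen. Compound 1 and compound 2 differ in several places at once, and their values lie within the scatter of each other. So nothing measured here speaks directly to lengthening the chain on that nitrogen, and the one step that exists was flat.

On this basis compound 4 is expected to land close to compound 2 in this assay, with no step beyond the scatter, but with wide uncertainty. The estimated step is no change at the digits printed from compound 2 to compound 4 (within the scatter). Compound 4 is therefore estimated at 1400 nM, with a range from 450 nM to 4500 nM.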

Compound 4, half-maximal inhibitory concentration: 10000 nM
The estimate for compound 4 lay 7.1-fold (0.85 log units) below the measured number; measured number outside the range, above it.
By their numbers in this assay, from the lowest: compounds 1, 2 and 3 (each within the scatter of the next); then compound 4.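

In this assay, the chain on the nitrogen on an aromatic ring is not a place where any added group is tolerated: replacing ethyl with 3-(dimethylamino)propyl gives a 7.1-fold higher number from compound 2 to compound 4 (0.85 log units; beyond the scatter). The only earlier step that changes one place, a 1.1-fold higher number from compound 2 to compound 3 (0.03 log units; within the scatter), sits on an aromatic carbon and moved the number no further than the scatter, so this chain is the first place among these compounds shown to respond to a change. No measurement here accounts for the weaker inhibition, so the step records only the effect of the whole change.

The compounds shown cannot separate the effect of the longer chain from that of the dimethylamino group at its end, since both enter together in compound 4. A plain propyl group on the same nitrogen would test the chain alone, while a 2-(dimethylamino)ethyl group or a 3-hydroxypropyl group would show whether a shorter chain or a different end group changes the outcome.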